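Working notes: three measured compounds and a pyrimidinyl amide

A few compounds are considered here, and "the series" means these few. Any claim that something is new, unique, unknown or untested is made for them only; others in the source may bear on it.

Measured so far in an assay for inhibition of inositol hexakisphosphate kinase 2 (Homo sapiens), read by colorimetric assay, coupled enzyme assay and malachite green, with a stated time of 120 min, in the presence of a further agent that is not named here; a higher number here means a weaker inhibitor, a lower number a stronger inhibitor:
compound 1 `CNC(=O)/C=C/c1ccc2noc(-c3ccccc3)c2c1` gives 58200 nM
compound 2 `Cc1ccc(-c2onc3ccc(/C=C/C(=O)O)cc23)cc1` gives 6510 nM
compound 3 `CC(C)C(=O)Nc1ccc(-c2onc3ccc(C(=O)O)cc23)cc1` gives 820 nM

Compound 3 stands lowest of the three numbers in this assay, and its gaps to compound 2 and to compound 1 both lie beyond the scatter, so it is the strongest inhibitor measured here. Within the data shown here, no step between a pair of measured compounds differs in only one place, so the three values are read only as they stand.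

Compound 4 `O=C(O)c1ccc2noc(-c3ccc(NC(=O)c4ccncn4)cc3)c2c1` has not yet been measured in this assay. It differs from compound 3 in one place: pyrimidin-4-yl in place of isopropyl on a carbonyl carbon. The carboxylic acid and the shared core are kept, as is the amide-type nitrogen that carries the carbonyl.

Nothing measured in the series tests an exchange on this carbonyl carbon, so the direction of the step is open. With the acid and core unchanged, the expectation for compound 4 is a step of a 1.6-fold lower number from compound 3 to compound 4 (0.21 log units; within the scatter) that is not clearly beyond the scatter, leaning if anything toward a lower number. Compound 4 is therefore estimated at 500 nM, within a range from 150 nM to 2000 nM.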

Compound 4, half-maximal inhibitory concentration: 720 nM
Compound 4: middle estimate off by 1.4-fold (0.16 log units), on the low side; measured number inside the range.
By their numbers in this assay, from the lowest: compounds 4 and 3 (each within the scatter of the next); then compound 2; then compound 1.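

In this assay, among these compounds, pyrimidin-4-yl in place of isopropyl on a carbonyl carbon gives a 1.1-fold lower number from compound 3 to compound 4 (0.06 log units; within the scatter), the first exchange that can be read at a single place. The group on this carbonyl carbon can thus go from 3 heavy atoms and no ring to 6 heavy atoms in a six-membered aromatic ring with 2 hetero atoms and 2 hydrogen-bond acceptors, and compound 3 and compound 4 still cannot be told apart by their numbers. No measurement is at hand that bears on why the two groups read alike.

One exchange does not show how much this position tolerates in general, nor whether the ring or its nitrogen atoms matter to the number. A phenyl group on the same carbonyl carbon would separate the ring from its nitrogen atoms, while a cyclohexyl group or a longer alkyl chain would test other shapes and sizes with the carboxylic acid and the shared core kept.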